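The source may hold more compounds than are shown below. What is called first, only, known or untested is meant among the compounds shown, and "the series" means these compounds.

In a physicochemical assay for acid dissociation, compound 1 `COc1cccc(CNCCCNc2ccnc3cc(Oc4ccccc4)ccc23)c1O` gives 9.28. Compound 2 `CC(C)(C)c1ccc(Oc2ccc3c(NCCCNCc4ccco4)ccnc3c2)cc1` gives 9.28 in this assay, and compound 3 `COc1ccc(F)cc1CNCCCNc1ccnc2cc(Oc3ccc(F)cc3)ccc12` gives 9.28, so compound 1 stands level with both at the digits shown; compound 2 is the nearest and compound 3 the furthest, and neither separation rises above the scatter of repeated measurements.

Compound 4 `COc1cccc(CNCCCNc2ccnc3cc(-c4ccc(C(C)(C)C)cc4)ccc23)c1O` has not yet been measured in this assay. It differs from compound 1 in one place: 4-(tert-butyl)phenyl in place of phenoxy on an aromatic carbon. Going by the values given here, no step between two measured compounds that differ in a single place is available, so the size of this change cannot be read from a direct comparison. The three measured compounds nonetheless differ from one another at several points and still share one value, which points to a step of no size beyond the scatter. Compound 4 is therefore expected to give 9.28 in this assay, within a range from 8.95 to 9.6. The step that this expectation means is no change at the digits printed from compound 1 to compound 4 (within the scatter).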

Compound 4, acid dissociation constant: 9.47
For compound 4 the middle estimate is 0.19 log units below the measured one, and the stated range covers the measured number.
By their numbers in this assay, from the lowest: compounds 1, 2, 3 and 4 (each within the scatter of the next).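

In this assay, going by these compounds alone, 4-(tert-butyl)phenyl in place of phenoxy on this aromatic carbon gives a number 0.19 log units higher from compound 1 to compound 4 (within the scatter), the only single-place step available at this position. The swap exchanges a group of 7 heavy atoms carrying 1 hydrogen-bond acceptor for one of 10 heavy atoms carrying none, and even so the read-out stays within the scatter. Nothing shown here bears on why the number holds across this change.

The compounds shown leave open whether an amine or a carboxylic acid on this same aromatic carbon would also stay within the scatter. They also leave open whether the same swap gives a step of like size when the rest of the molecule differs from compound 1.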